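Notes on a para-substituent swap in a growth-inhibition series

The source may report more compounds than this note shows. Statements on the series, on what has been measured and on what is new or still open speak of the compounds shown alone.

Measured compounds:
compound 1 `CCOC(=O)[C@H](CCC(=O)O)NC(=O)c1ccc(CNc2nc3cc(N)cc(N)c3nc2-c2ccccc2)cc1` — < 100000 nM (a limit)
compound 2 `COc1ccc(CNc2nc3cc(N)cc(N)c3nc2-c2ccccc2)cc1` — 11500 nM
compound 3 `COc1ccc(Sc2nc3cc(N)cc(N)c3nc2-c2ccccc2)cc1` — 4170 nM

In a functional assay on UO-31 cells (Homo sapiens) for inhibition, read by sulforhodamine B assay, with a stated time of 48 h (on this read-out higher numbers stand for weaker inhibition of growth and lower numbers for stronger inhibition of growth), compound 1 gives only a limit, < 100000 nM, and no number. Compound 2 gives 11500 nM and compound 3 gives 4170 nM; compound 3 therefore holds the lower of the two numbers shown, and its gap to compound 2 lies beyond the usual scatter. Compound 4 `Nc1cc(N)c2nc(-c3ccccc3)c(Sc3ccc(F)cc3)nc2c1` differs from compound 3 by fluoro in place of methoxy on an aromatic carbon. Going by the values given here, no measured pair shows this change, so its size here is not known. The expected step of a 1.2-fold higher number from compound 3 to compound 4 (0.08 log units; within the scatter) is small, within the scatter, in either direction. Compound 4 is expected near 5000 nM, between 1500 nM and 16000 nM.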

Compound 4, concentration for 50% growth inhibition: < 100000 nM
Compound 4: only a limit was reported; the forecaster's own chance of this, stated with the estimate: 5%; the middle value lies beyond the limit too.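

In this assay, going by these compounds alone, compound 4 gives only a limit, < 100000 nM, so no step from compound 3 can be read. As far as these compounds go, the size and direction of the change from methoxy to fluoro on this aromatic carbon remain open.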